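A few compounds are considered here, and "the series" means these few. Any claim that something is new, unique, unknown or untested is made for them only; others in the source may bear on it.

Going by the values given here, in a functional assay on HeLa cells (Homo sapiens) for antiproliferative activity, read by sulforhodamine B assay, with a stated time of 48 h (on this read-out lower numbers stand for stronger inhibition and higher numbers for weaker inhibition), compound 1 (`COc1ccc(C(=O)/C=C\Nc2ccc(-c3nc4cc(OC)c(OC)c(OC)c4s3)cc2C)cc1F`) gives 1200 nM, the lowest of the three numbers so far. Compound 2 (`COc1ccc(C(=O)/C=C\Nc2ccc(-c3nc4cc(OC)c(OC)c(OC)c4s3)cc2C)cc1[N+](=O)[O-]`) gives 13400 nM, and compound 3 (`COc1cc(OC)c2sc(-c3ccc(N/C=C\C(=O)c4ccc(OC)c(F)c4)c(C)c3)nc2c1`) gives 14700 nM. Compound 4 (`COc1ccc(C(=O)/C=C\Nc2ccc(-c3nc4cc(OC)c(OC)c(OC)c4s3)cc2)cc1F`) has hydrogen in place of methyl on an aromatic carbon. Two measured steps offer only indirect guidance: an 11-fold higher number from compound 1 to compound 2 (1.05 log units; beyond the scatter) and a 12-fold higher number from compound 1 to compound 3 (1.09 log units; beyond the scatter). Both are large and both raise the number, but neither changes this methyl, so neither gives the size of this step. The expected step is therefore modest, a 1.3-fold higher number from compound 1 to compound 4 (0.10 log units; within the scatter), with no shift beyond the scatter expected but a wide range that leans upward. For compound 4 the estimated value is 1500 nM, with an expected range from 350 nM to 8000 nM.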

Compound 4, half-maximal inhibitory concentration: 7300 nM
For compound 4 the middle estimate is 4.9-fold (0.69 log units) below the measured one; low and high end bracket the measured number.
By their numbers in this assay, from the lowest: compound 1; then compounds 4, 2 and 3 (each within the scatter of the next).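

Hydrogen in place of methyl on this aromatic carbon, ortho to one large group and meta to another, gives a 6.1-fold higher number from compound 1 to compound 4 (0.78 log units; beyond the scatter) in this assay. Going by these compounds alone, the earlier compounds all carry this methyl, so only this step shows that losing one carbon here weakens inhibition beyond the scatter. Nothing available explains why this happens.

As far as these compounds go, whether an ethyl group or a chlorine atom at this position would match the methyl remains open. It is also unknown whether the methyl counts for as much alongside the nitro group or without the methoxy group.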